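Thiocarbamate in place of mesylate on the shared core

The source may report more compounds than this note shows. Statements on the series, on what has been measured and on what is new or still open speak of the compounds shown alone.

Measured compounds:
compound 1 `Fc1cccc(-c2ccc(/C=C/[C@H]3C(OCc4ccccc4)C[C@@H]4CCCC[C@@H]43)nc2)c1`: in an assay on cell membranes for displacement of a labelled ligand from proteinase-activated receptor 1 (Homo sapiens), read by scintillation counting, with a stated time of 60 min (a lower number here means a stronger inhibitor, a higher number a weaker inhibitor), compound 1 gives 280 nM.
compound 2 `CC(=O)OC1C[C@@H]2CCCC[C@@H]2[C@H]1/C=C/c1ccc(-c2cccc(F)c2)cn1`: in this assay compound 2 gives 67 nM.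
compound 3 `CS(=O)(=O)OC1C[C@@H]2CCCC[C@@H]2[C@H]1/C=C/c1ccc(-c2cccc(F)c2)cn1`: in this assay compound 3 gives 6.4 nM.

Compound 3 stands lowest of the three numbers; the nearest is compound 2, at a 10-fold lower number from compound 2 to compound 3 (1.02 log units; beyond the scatter), the furthest compound 1, at a 44-fold lower number from compound 1 to compound 3 (1.64 log units; beyond the scatter). The whole series differs only at the oxygen on the saturated carbon: the step of a 4.2-fold lower number from compound 1 to compound 2 (0.62 log units; beyond the scatter) is modest, the two steps onto the methylsulfonyl are large.

Compound 4 `CN(C)C(=S)OC1C[C@@H]2CCCC[C@@H]2[C@H]1/C=C/c1ccc(-c2cccc(F)c2)cn1` is not yet measured. The change is a group of 5 heavy atoms (3 carbon, 1 nitrogen, 1 sulfur; no ring) in place of a group of 4 heavy atoms (1 carbon, 2 oxygen, 1 sulfur; no ring), on an oxygen on a saturated carbon. All three measured steps bear on it, since each swaps the group on that oxygen, and together they show that this position moves the number well beyond the scatter. The group entering is not a sulfonyl, so the expected number for compound 4 lies nearer to compound 2 than to compound 3: a rise of a 6.3-fold higher number from compound 3 to compound 4 (0.80 log units; beyond the scatter) is expected, and compound 4 is estimated at 40 nM, within 10 nM to 160 nM.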

Compound 4, half-maximal inhibitory concentration: 120 nM
Compound 4: middle estimate off by 3.0-fold (0.48 log units), on the low side, and the stated range covers the measured number.
By their numbers in this assay, from the lowest: compound 3; then compounds 2 and 4 (each within the scatter of the next); then compound 1.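

In this assay, a second non-aromatic group carrying sulfur does not reproduce what the methylsulfonyl gives on this oxygen: the thiocarbamate shows a 19-fold higher number from compound 3 to compound 4 (1.27 log units; beyond the scatter). Against the acetyl it makes no readable difference, at a 1.8-fold higher number from compound 2 to compound 4 (0.25 log units; within the scatter), while against the benzyl a modest gain remains, at a 2.3-fold lower number from compound 1 to compound 4 (0.37 log units; beyond the scatter), so among the four groups the large steps at this position all involve the methylsulfonyl. No measurement at hand explains this difference.

The compounds shown cannot separate an effect of the sulfonyl as such from one specific to the methylsulfonyl, which an ethylsulfonyl or phenylsulfonyl on this oxygen would address. They also do not tell how the free hydroxyl, or a carbamate with oxygen in place of the thiocarbamate sulfur, would read.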